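A few compounds are considered here, and "the series" means these few. Any claim that something is new, unique, unknown or untested is made for them only; others in the source may bear on it.

Measured compounds:
compound 1, `CS(=O)(=O)Nc1ccc(-c2cc(C(=O)N[C@H]3CCCNC3)c(NC(N)=O)s2)cc1`: "not determined" (no result reported) in an assay on isolated protein for inhibition of cyclin-dependent kinase 2-associated protein 1 (Homo sapiens); a lower number here means a stronger inhibitor, a higher number a weaker inhibitor
compound 2, `Cc1ccc(-c2cc(C(=O)N[C@H]3CCCNC3)c(NC(N)=O)s2)cc1`: 5500 nM
compound 3, `CN(C)C(=O)c1ccc(-c2cc(C(=O)N[C@H]3CCCNC3)c(NC(N)=O)s2)cc1`: 3700 nM

Compound 2 carries the highest of the two numbers that were obtained in this assay, but compound 3 sits close to it: the change from compound 2 to compound 3 reads a 1.5-fold lower number from compound 2 to compound 3 (0.17 log units; within the scatter), so the two numbers cannot be told apart. Compound 1 contributes no number.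

Compound 4, `NC(=O)Nc1sc(-c2ccc(Cl)cc2)cc1C(=O)N[C@H]1CCCNC1`, differs from compound 2 in one place: chloro in place of methyl on an aromatic carbon. Among the measured compounds shown here, the only measured step that speaks to this position is the one from compound 2 to compound 3, where a dimethylcarbamoyl replaced the methyl on the same aromatic carbon and the number hardly moved, staying within the scatter. With a single such comparison, and one that shows no clear movement, there is no basis to expect a shift beyond the scatter when chloro replaces methyl on that aromatic carbon. Compound 4 is therefore expected to give about 5000 nM in this assay, with a plausible span from 2000 nM to 12000 nM. The step this implies, a 1.1-fold lower number from compound 2 to compound 4 (0.04 log units; within the scatter), is expected to remain within the usual scatter.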

Compound 4, half-maximal inhibitory concentration: 3700 nM
Compound 4: the middle estimate sits 1.4-fold (0.13 log units) above what was measured; low and high end bracket the measured number.
By their numbers in this assay, from the lowest: compounds 3, 4 and 2 (each within the scatter of the next).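

In this assay, compound 4 adds a second substituent comparison at this position, and the change from 4-methylphenyl to 4-chlorophenyl reads a 1.5-fold lower number from compound 2 to compound 4 (0.17 log units; within the scatter) in this series. Set against the larger dimethylcarbamoyl group on the same aromatic carbon, the step reads no change at the digits printed from compound 3 to compound 4 (within the scatter) and so gives no separation either. The earlier compounds offered only one comparison at this site, whereas methyl, dimethylcarbamoyl and chloro, each para to a large group, now form a set of three that this assay cannot tell apart, so swapping one of these groups for another on this carbon has shown no measurable consequence. Nothing given here explains why these compounds stay so close together.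

What the compounds shown leave open is whether any group at this position can move the number beyond the scatter, for example an amine, a carboxylic acid or a longer chain. They also leave open whether a change elsewhere on the shared core would matter more than any of the changes at this aromatic carbon.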